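This account rests on a few compounds, and the source may have more. Where it says the series, first, only, none or still open, it means among the compounds named here.

Compound 1 `Cc1ccc2c(c1)/C(=N/NC(=S)Nc1ccccc1)C(=O)N2`: in an ADME assay on RD cells (Homo sapiens) for cytotoxicity (on this read-out lower numbers stand for higher toxicity in this test and higher numbers for lower toxicity in this test), compound 1 gives > 25000 nM, a limit of the test rather than a number.
Compound 2 `O=C1Nc2ccccc2/C1=N/NC(=S)Nc1ccccc1`: compound 2 gives > 25000 nM, again only a limit.
Compound 3 `COc1ccccc1NC(=S)N/N=C1\C(=O)Nc2ccccc21`: compound 3 gives > 25000 nM, also a limit.

Compound 2 thus stands nowhere on a scale but at the limit of > 25000 nM in this assay, at which 3 of the 3 values shown sit, where every measured value here rests. Compound 4 `COc1ccc2c(c1)/C(=N/NC(=S)Nc1ccccc1)C(=O)N2` differs from compound 2 in one place: methoxy in place of hydrogen on an aromatic carbon. The two measured steps that touch compound 2 are a step that the two limits leave unreadable from compound 1 to compound 2 and a step that the two limits leave unreadable from compound 2 to compound 3; both run from one limit to another, so neither tells how large a change of this kind is. No step beyond the scatter can be expected for a step that the limit leaves unreadable from compound 2 to compound 4. Compound 4 is therefore estimated at 40000 nM, within 20000 nM to 100000 nM, and most likely reported again as a limit only.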

Compound 4, half-maximal cytotoxic concentration: > 25000 nM
Compound 4: a limit, no number; the forecaster's own chance of this, stated with the estimate: 85%; the middle value is on the limit's open side.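

The steps from compound 1 and from compound 2 to compound 4 cannot be read: each runs between two limits of the test. The compounds shown leave open whether any of these swaps on an aromatic carbon changes the result in this assay at all, and by how much.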